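This account rests on a few compounds, and the source may have more. Where it says the series, first, only, none or still open, it means among the compounds named here.

Compound 1 `NC(=O)N1CCN(C(=S)SCc2cn(Cc3ccc(F)cc3)nn2)CC1` and compound 2 `CCNC(=O)N1CCN(C(=S)SCc2cn(Cc3ccc(F)cc3)nn2)CC1` share one core and differ only in ethyl in place of hydrogen on an amide-type nitrogen. In a functional assay on EC9706 cells (Homo sapiens) for cytotoxicity, read by MTT assay, with a stated time of 72 h (a higher number here means a weaker inhibitor, a lower number a stronger inhibitor), compound 1 gives 62700 nM, and compound 2 gives 27800 nM; that is a 2.3-fold lower number from compound 1 to compound 2 (0.35 log units; beyond the scatter). Compound 3 `COc1cc(Cn2cc(CSC(=S)N3CCN(C(N)=O)CC3)nn2)cc(OC)c1OC` carries a different core, and the difference between the two cores is not broken down here. In this assay compound 3 reaches only a limit, > 128000 nM, which is the limit of > 128000 nM in this assay, at which 1 of the 3 values shown sits, rather than a number. Among the measured compounds shown here, compound 4 `CCNC(=O)N1CCN(C(=S)SCc2cn(Cc3cc(OC)c(OC)c(OC)c3)nn2)CC1` has not yet been measured in this assay; it differs from compound 3 by ethyl in place of hydrogen on an amide-type nitrogen, the same change as the one from compound 1 to compound 2, at the same place. If that change carried over, compound 4 would be expected to give a step of about an at least 1.4-fold lower number from compound 3 to compound 4 (0.15 log units; that floor lies within the scatter) from compound 3, resting on the step from compound 1 to compound 2 a 2.3-fold lower number from compound 1 to compound 2 (0.35 log units; beyond the scatter), though the start is a limit and not a number. Compound 4 is therefore estimated at around 90000 nM in this assay, between 30000 nM and 300000 nM, with a real chance that only a limit is reported again.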

Compound 4, half-maximal inhibitory concentration: > 128000 nM
Compound 4: no number, only a limit; the forecaster's own chance of this, stated with the estimate: 50%; middle value at least 1.4-fold (0.15 log units) from the limit.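

In this assay, compound 3 and compound 4 both stand at a limit and not at a number, so no step between them can be read: the limit of > 128000 nM in this assay, at which 2 of the 4 values shown sit.

The compounds shown leave open whether ethyl in place of hydrogen on an amide-type nitrogen changes the reading at all on the core of compound 3.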